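A Second Chloro Added to a Weakly Cytotoxic Core

The source may report more compounds than this note shows. Statements on the series, on what has been measured and on what is new or still open speak of the compounds shown alone.

Measured compounds:
Compound 1, `ClCc1ccccc1Cn1cnc2c(Cl)nc(Cl)nc21`, "not determined" (no result reported)
Compound 2, `ClCc1ccccc1Cn1cnc2c(Cl)ncnc21`, > 100000 nM
Compound 3, `ClCc1cccc(Cn2cnc3c(Cl)ncnc32)c1`, 74100 nM

Three compounds share one core and differ only in where the chloromethyl arm sits on the benzyl ring and in how many chloro groups the core carries. In a functional assay on COLO 205 cells (Homo sapiens) for cytotoxicity, read by sulforhodamine B assay, with a stated time of 48 h (on this read-out lower numbers stand for higher toxicity in this test and higher numbers for lower toxicity in this test), compound 1 has "not determined" (no result reported), so it offers no number to compare. For compound 2 the read-out in this assay is a limit rather than a number, > 100000 nM. Compound 2 thus accounts for (the limit of > 100000 nM in this assay, at which 1 of the 3 values shown sits). Among the compounds with values here, compound 3 gives 74100 nM in this assay, and this is the only genuine number in the set. The other two entries supply no single number. Within the data shown here, since no two measured compounds differ in a single place, no step can be read from these three entries.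

Compound 4, `ClCc1cccc(Cn2cnc3c(Cl)nc(Cl)nc32)c1`, is compound 3 with chloro in place of hydrogen on an aromatic carbon. Among the measured compounds shown here, no comparable step has been measured, so the expected change from compound 3 to compound 4 in this assay is a 1.5-fold lower number from compound 3 to compound 4 (0.17 log units; within the scatter), a shift not expected to exceed the usual scatter. Compound 4 is therefore estimated at 50000 nM in this assay, with a likely range from 15000 nM to 150000 nM.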

Compound 4, concentration lethal to 50% of the cells: > 100000 nM
Compound 4 ended at the assay's limit (the forecaster's own chance of this, stated with the estimate: 30%); middle value at least 2.0-fold (0.30 log units) from the limit.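

Within the data shown here, this is the first step in the set that can be read, and it concerns the carbon between two ring nitrogen atoms on the shared core: with chloro in place of hydrogen there, this assay shows an at least 1.3-fold higher number from compound 3 to compound 4 (0.13 log units; that floor lies within the scatter). On these data alone, only a floor is known for this step, and that floor cannot separate the change from ordinary repeat variation, so its true size remains unknown, though the added chloro brought no sign of higher toxicity in this test. Among these compounds, compound 4 has a limit of the assay rather than a number, which leaves compound 3 as the only compound with a genuine number and puts compound 4 alongside compound 2: the limit of > 100000 nM in this assay, at which 2 of the 4 values shown sit.

Still open, as far as these compounds go, is whether a different group on this same carbon, such as an amine or a methoxy group, would give a true number in this assay rather than a limit. From the compounds shown here alone, the step between compound 1 and compound 2 cannot be read, so it also remains unknown whether chloro at this carbon would have a comparable outcome with the chloromethyl arm placed as it is in those two compounds.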